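Chain length and the imidazolylalkyl substituent on the core

A few compounds are considered here, and "the series" means these few. Any claim that something is new, unique, unknown or untested is made for them only; others in the source may bear on it.

The study measured two compounds of a shared core in a functional assay on ECa-109 cells (Homo sapiens) for antiproliferative activity, read by MTT assay, with a stated time of 48 h; on this read-out lower numbers stand for stronger inhibition and higher numbers for weaker inhibition. Compound 1 `Cn1cc(C2=C(c3nn(CCCn4ccnc4)c4ncccc34)C(=O)NC2=O)c2ccccc21` carries a 3-(1H-imidazol-1-yl)propyl group on an aromatic nitrogen; in this assay compound 1 reaches only the limit > 100000 nM, which is a limit of the assay and not a number. Compound 2 `Cn1cc(C2=C(c3n[nH]c4ncccc34)C(=O)NC2=O)c2ccccc21` bears hydrogen at that place instead, and in this assay compound 2 gives 46100 nM, the only number shown among the two values. The step from the substituted to the unsubstituted compound was an at least 2.1-fold lower number from compound 1 to compound 2 (0.33 log units; beyond the scatter).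

Compound 3 `Cn1cc(C2=C(c3nn(CCCCn4ccnc4)c4ncccc34)C(=O)NC2=O)c2ccccc21` returns a substituent at the same position: 4-(1H-imidazol-1-yl)butyl in place of hydrogen on an aromatic nitrogen. For the measured compounds named here, the one relevant step, from compound 1 to compound 2, went toward a lower number when such a group was removed, and the result for compound 1 sat at the limit of > 100000 nM in this assay, at which 1 of the 2 values shown sits. Compound 3 is therefore expected to move back toward weaker inhibition, the estimated step being a 2.4-fold higher number from compound 2 to compound 3 (0.38 log units; beyond the scatter). Compound 3 is estimated at 110000 nM, within 40000 nM to 300000 nM, with a real chance that this assay again reports only a limit.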

Compound 3, half-maximal inhibitory concentration: 23500 nM
Compound 3: middle estimate off by 4.7-fold (0.67 log units), on the high side; measured number outside the range, below it.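

In this assay, the step from hydrogen to the 4-(1H-imidazol-1-yl)butyl group, a 2.0-fold lower number from compound 2 to compound 3 (0.29 log units; within the scatter), stays within the scatter, so the two compounds cannot be told apart and a group on this aromatic nitrogen does not by itself weaken the read-out. The chain matters instead: adding one carbon to the chain gives an at least 4.2-fold lower number from compound 1 to compound 3 (0.62 log units; beyond the scatter), a step beyond the scatter. That step rests on compound 1, whose value is a limit of the assay and not a number: the limit of > 100000 nM in this assay, at which 1 of the 3 values shown sits.

With only the 3-(1H-imidazol-1-yl)propyl and 4-(1H-imidazol-1-yl)butyl chains shown, two lengths cannot establish a trend with chain length. From the compounds shown here alone, it also remains open how a longer chain would read, or whether an amine in place of the 1H-imidazol-1-yl group would give the same result.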